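The source may report more compounds than this note shows. Statements on the series, on what has been measured and on what is new or still open speak of the compounds shown alone.

Of the compounds shown here, three sharing one core have been measured in a physicochemical assay for lipophilicity, using the shake flask method, in phosphate buffer, measured as octanol-water partition, with a stated time of 30 min, at pH 7.4; on this read-out lower numbers stand for lower lipophilicity and higher numbers for higher lipophilicity. Compound 1 (`Cc1nccn1-c1cnc(NCc2c(F)ccc3c2CCO3)c2cn[nH]c(=O)c12`) gives 2.1, compound 2 (`O=C1CCCN1c1cnc(NCc2c(F)ccc3c2CCO3)c2cn[nH]c(=O)c12`) gives 1.8, and compound 3 (`CNC(=O)c1ncc(-c2cnc(NCc3c(F)ccc4c3CCO4)c3cn[nH]c(=O)c23)n1C`) gives 2.5, the highest of the three numbers. Compound 4 (`CN(c1ccn(C)n1)c1cnc(NCc2c(F)ccc3c2CCO3)c2cn[nH]c(=O)c12`) has not yet been measured. It carries methyl(1-methyl-1H-pyrazol-3-yl)amino in place of 1-methyl-2-(methylcarbamoyl)-1H-imidazol-5-yl on an aromatic carbon, and the exchange comes to this: methyl(1-methyl-1H-pyrazol-3-yl)amino in place of 1-methyl-2-(methylcarbamoyl)-1H-imidazol-5-yl on an aromatic carbon.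

Among the compounds with values here, no measured compound carries the entering group, so the data cannot give this step directly. Within the data shown here, the three measured steps are exchanges at the same place, and they show only how far such exchanges have moved the number so far. The record shows a number 0.30 log units lower from compound 1 to compound 2 (within the scatter), then a number 0.40 log units higher from compound 1 to compound 3 (beyond the scatter), and the largest is a number 0.70 log units higher from compound 2 to compound 3 (beyond the scatter). All three are small to modest, and compound 3 sits at the top of this narrow span. A small downward move in this assay is therefore expected, possibly none beyond the scatter. The estimated step is a number 0.10 log units lower from compound 3 to compound 4 (within the scatter). For compound 4 the expected value is 2.4, with an estimated range from 1.9 to 2.9.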

Compound 4, distribution coefficient: 2.4
Estimate against measurement, compound 4: no gap at the digits printed; low and high end bracket the measured number.
By their numbers in this assay, from the lowest: compounds 2, 1, 4 and 3 (each within the scatter of the next, the first and the last beyond it).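

In this assay, the exchange at this aromatic carbon removes the hydrogen-bond donor and the carbonyl of 1-methyl-2-(methylcarbamoyl)-1H-imidazol-5-yl and brings in methyl(1-methyl-1H-pyrazol-3-yl)amino, yet the record gives a number 0.10 log units lower from compound 3 to compound 4 (within the scatter) and so does not separate the two groups. The entering group also stands close to 2-methyl-1H-imidazol-1-yl, with a number 0.30 log units higher from compound 1 to compound 4 (within the scatter) as the step, whereas 2-oxopyrrolidin-1-yl stays apart from it, with a number 0.60 log units higher from compound 2 to compound 4 (beyond the scatter) as the step. Four different groups on this aromatic carbon therefore leave the number inside the span already set by compound 2 and compound 3, and a group attached through a nitrogen that carries a methyl and an aromatic ring does not extend that span.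

Nothing in the material accounts for any of these numbers. From the compounds shown here alone, it remains open whether a simple dimethylamino group, a carboxylic acid or a longer alkyl chain on this aromatic carbon would stay inside the same span, and whether replacing the methyl on the linking nitrogen with hydrogen would move the number.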